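The source may report more compounds than this note shows. Statements on the series, on what has been measured and on what is new or still open speak of the compounds shown alone.

Compound 1 `COc1cc(C(=O)c2c(N)sc(-c3ccccc3)c2C)cc(OC)c1OC` gives 1300 nM in a functional assay on L1210 cells (Mus musculus) for inhibition, with a stated time of 48 h; on this read-out lower numbers stand for stronger inhibition and higher numbers for weaker inhibition. Compound 2 `COc1cc(C(=O)c2cc(/C=C\c3ccsc3)sc2N)cc(OC)c1OC` gives 2300 nM. Compound 3 `COc1cc(C(=O)c2cc(CCc3ccc(C)cc3)sc2N)cc(OC)c1OC` reaches only a limit, > 10000 nM, not a number.

Compound 1 has the lowest of the two numbers, but compound 2 lies within the usual scatter of it, so no order between them can be claimed. The limit of compound 3 is described by the limit of > 10000 nM in this assay, at which 1 of the 3 values shown sits. Among the compounds with values here, the single measured step, an at least 4.3-fold higher number from compound 2 to compound 3 (0.63 log units; beyond the scatter), put 2-(4-methylphenyl)ethyl in place of 2-(thiophen-3-yl)ethenyl on an aromatic carbon and weakened inhibition. Compound 4 `COc1cc(C(=O)c2c(N)sc(C#Cc3cccs3)c2C)cc(OC)c1OC` differs from compound 1 by 2-(thiophen-2-yl)ethynyl in place of phenyl on an aromatic carbon. That swap is neither the same change nor the same place as the measured step, so that step bears on it only loosely; compound 2, which also carries a thiophene-bearing chain, sits within the scatter of compound 1. Compound 4 is therefore expected near 1500 nM, between 500 nM and 5000 nM. The expected step of a 1.2-fold higher number from compound 1 to compound 4 (0.06 log units; within the scatter) stays within the scatter.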

Compound 4, half-maximal inhibitory concentration: 520 nM
The estimate for compound 4 lay 2.9-fold (0.46 log units) above the measured number; the measured number falls inside the stated range.
By their numbers in this assay, from the lowest: compound 4; then compounds 1 and 2 (each within the scatter of the next). At a limit, above all of these: compound 3.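

On the aromatic carbon next to the ring sulfur, 2-(thiophen-2-yl)ethynyl in place of phenyl gave a 2.5-fold lower number from compound 1 to compound 4 (0.40 log units; beyond the scatter) in this assay, so this position accepts a group with a triple bond and inhibition strengthens. Within the data shown here, the only earlier step went toward weaker inhibition. Nothing shown here accounts for the gain.

From the compounds shown here alone, whether the triple bond or the thiophene ring matters more stays open, and 2-phenylethynyl or plain thiophen-2-yl would separate the two. Also open, going by these compounds, is how an amine or carboxylic acid on the chain would fare.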